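This account rests on a few compounds, and the source may have more. Where it says the series, first, only, none or still open, it means among the compounds named here.

Working notes on the series. For the measured compounds named here, compound 3 `COC(=O)[C@H](CC(C)C)NC(=O)c1ccc(C(=O)NC[C@H]2COc3ccccc3O2)cc1-c1ccccc1OC` gives 185000 nM in a functional assay (HSMC cells, Homo sapiens) for antiproliferative activity, with a stated time of 72 h (on this read-out lower numbers stand for stronger inhibition and higher numbers for weaker inhibition), which places it second highest of the three numbers measured so far. Its nearest neighbour is compound 2 `COC(=O)CNC(=O)c1ccc(C(=O)NC[C@@H]2COc3ccccc3O2)cc1-c1ccccc1OC`, which in this assay gives 76000 nM, a number lower than that of compound 3 by more than the scatter. Furthest from it is compound 1 `COC(=O)[C@H](CCSC)NC(=O)c1ccc(C(=O)NC[C@@H]2COc3ccccc3O2)cc1-c1ccccc1OC`, which gives 647000 nM in this assay, higher than compound 3 by more than the scatter.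

Going by the values given here, the one step measured within one change, an 8.5-fold lower number from compound 1 to compound 2 (0.93 log units; beyond the scatter), concerns the replacement of a side chain on the saturated chain carbon and so does not bear on the change now considered. Compound 4 `COC(=O)[C@H](CC(C)C)NC(=O)c1ccc(C(=O)NC[C@@H]2COc3ccccc3O2)cc1-c1ccccc1OC` differs from compound 3 only in configuration: the two compounds have the same atoms and bonds and differ only in configuration as drawn: 1 of 2 stereo elements differ; a stereocentre at a saturated ring carbon is drawn S in compound 3 and R in compound 4. Among the compounds with values here, no measured pair isolates this stereocentre, so there is no direct precedent; the expectation is therefore a step within the scatter in either direction. On that basis compound 4 is estimated at 160000 nM in this assay, with a range from 55000 nM to 480000 nM. The step this implies, a 1.2-fold lower number from compound 3 to compound 4 (0.06 log units; within the scatter), is expected to stay within the scatter.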

Compound 4, half-maximal inhibitory concentration: 469000 nM
Estimate against measurement, compound 4: 2.9-fold (0.47 log units) below; the measured number falls inside the stated range.
By their numbers in this assay, from the lowest: compound 2; then compound 3; then compounds 4 and 1 (each within the scatter of the next).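

With the isobutyl side chain held constant, the ring stereocentre drawn R instead of S gives a 2.5-fold higher number from compound 3 to compound 4 (0.40 log units; beyond the scatter) in this assay, so this centre alone moves the number, a reading that rests on one fact: the fact that compounds 3 and 4 differ only in the configuration as drawn. With the ring centre drawn R, isobutyl in place of hydrogen on the saturated chain carbon gives a 6.2-fold higher number from compound 2 to compound 4 (0.79 log units; beyond the scatter), the same direction as the earlier comparison of hydrogen with 2-(methylsulfanyl)ethyl. The isobutyl and 2-(methylsulfanyl)ethyl side chains are not separated by this assay: a 1.4-fold lower number from compound 1 to compound 4 (0.14 log units; within the scatter).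

On these data alone, whether the ring stereocentre gives a similar step with hydrogen or 2-(methylsulfanyl)ethyl on the chain carbon remains open. Also open, as far as these compounds go, is how a carboxylic acid in place of the methyl ester would read.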